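This account rests on a few compounds, and the source may have more. Where it says the series, first, only, none or still open, it means among the compounds named here.

Measured compounds in a functional assay on PANC-1 cells (Homo sapiens) for inhibition, read by MTT assay, with a stated time of 24 h; on this read-out higher numbers stand for weaker inhibition and lower numbers for stronger inhibition:

compound 1, `CC1(C)[C@H]2CC[C@]1(C)N(Cc1cn(-c3ccc(Cl)cc3)nn1)C(=O)C2`: 440 nM
compound 2, `CC1(C)[C@H]2CC[C@]1(C)N(Cc1cn(-c3ccccc3)nn1)C(=O)C2`: 160 nM
compound 3, `CC1(C)[C@H]2CC[C@]1(C)N(Cc1cn(-c3ccccc3Br)nn1)C(=O)C2`: 280 nM

Compound 2 holds the lowest of the three numbers. Its gap to compound 3 is within the scatter, so no order can be read between those two; its gap to compound 1 is beyond the scatter, a 2.8-fold lower number from compound 1 to compound 2 (0.44 log units; beyond the scatter). Going by the values given here, the only other single-point steps are a 1.8-fold higher number from compound 2 to compound 3 (0.24 log units; within the scatter) and a 1.6-fold lower number from compound 1 to compound 3 (0.20 log units; within the scatter), both within the scatter.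

Compound 4, `CC1(C)[C@H]2CC[C@]1(C)N(Cc1cn(-c3cccc(F)c3)nn1)C(=O)C2`, differs from compound 2 in one place: fluoro in place of hydrogen on an aromatic carbon. Among the compounds with values here, the steps that bear on this are those that put a chloro or a bromo onto the same ring of the shared core in place of hydrogen. Going from compound 2 to compound 3, bromo in place of hydrogen gave a 1.8-fold higher number from compound 2 to compound 3 (0.24 log units; within the scatter); going the other way, from compound 1 to compound 2, removing chloro gave a 2.8-fold lower number from compound 1 to compound 2 (0.44 log units; beyond the scatter). Neither place matches the new one, and fluoro has not been measured in this series, so the expectation rests on the direction alone: a small rise in the number, most likely within the scatter, is expected, a 1.4-fold higher number from compound 2 to compound 4 (0.14 log units; within the scatter).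

Compound 4 is therefore estimated at 220 nM, with a range of 110 nM to 450 nM.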

Compound 4, half-maximal inhibitory concentration: 220 nM
Beside the measured number, compound 4's estimate shows no gap at the digits printed; low and high end bracket the measured number.
By their numbers in this assay, from the lowest: compounds 2, 4, 3 and 1 (each within the scatter of the next, the first and the last beyond it).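

In this assay, the fluoro on the aromatic carbon meta to a large group gives a 1.4-fold higher number from compound 2 to compound 4 (0.14 log units; within the scatter), so this position accepts fluoro in place of hydrogen without a change that can be read. Compound 4 also cannot be separated from either halogen-bearing compound, with a 1.3-fold lower number from compound 3 to compound 4 (0.10 log units; within the scatter) and a 2.0-fold lower number from compound 1 to compound 4 (0.30 log units; within the scatter), so the only gap beyond the scatter in the series remains a 2.8-fold lower number from compound 1 to compound 2 (0.44 log units; beyond the scatter), and 3-fluorophenyl does not share that gap with phenyl. No measured evidence bears on this result.

The shown compounds leave open whether chloro or bromo on this same carbon would read differently from fluoro, since each of those halogens appears on the ring only at another place. They also leave open whether a group of a different kind at this carbon, such as an amine, a carboxylic acid or a longer chain, would move the number beyond the scatter in either direction.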